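A few compounds are considered here, and "the series" means these few. Any claim that something is new, unique, unknown or untested is made for them only; others in the source may bear on it.

Measured in a functional assay on COLO 205 cells (Homo sapiens) for inhibition, read by sulforhodamine B assay, with a stated time of 48 h, tested at 50 uM; on this read-out lower numbers stand for less inhibition of growth and higher numbers for more inhibition of growth at the one concentration tested:
- compound 1 `COc1cc(/C=C/C(=O)/C=C/c2cccc3ccccc23)ccc1OCc1cn(CCOc2cc(=O)oc3ccccc23)nn1`: 85%
- compound 2 `COc1cccc(/C=C/C(=O)/C=C/c2ccc(OCc3cn(CCCCOc4cc(=O)oc5ccccc45)nn3)c(OC)c2)c1`: 46%
- compound 3 `COc1cc(/C=C/C(=O)/C=C/c2cc(OC)c(OC)c(OC)c2)ccc1OCc1cn(CCOc2cc(=O)oc3ccccc23)nn1`: 86%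

Compound 2 stands lowest of these three, well beyond the scatter from both others. Compound 4 `COc1cc(/C=C/C(=O)/C=C/c2cc(OC)c(OC)c(OC)c2)ccc1OCc1cn(CCCCOc2cc(=O)oc3ccccc23)nn1`, not yet measured, carries 3,4,5-trimethoxyphenyl in place of the 3-methoxyphenyl of compound 2, on a double-bonded chain carbon bound to a double-bonded chain carbon: 3,4,5-trimethoxyphenyl in place of 3-methoxyphenyl on a double-bonded chain carbon bound to a double-bonded chain carbon. For the measured compounds named here, the only measured step that brings in this same group, there replacing naphthalen-1-yl, is a number 1 percentage points higher from compound 1 to compound 3 (within the scatter), so no change beyond the scatter is expected in this assay. A single step starting from a different group is thin evidence, which calls for a wide range. The expected step is a number 4 percentage points higher from compound 2 to compound 4 (within the scatter). Compound 4 is estimated at 50%, with an expected range from 33% to 74%.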

Compound 4, percent growth inhibition at one concentration: 60%
The estimate for compound 4 lay 10 percentage points below the measured number, and the stated range covers the measured number.
By their numbers in this assay, from the lowest: compound 2; then compound 4; then compounds 1 and 3 (each within the scatter of the next).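

The change from 3-methoxyphenyl to 3,4,5-trimethoxyphenyl in this assay gives a number 14 percentage points higher from compound 2 to compound 4 (beyond the scatter) on a double-bonded chain carbon bound to a double-bonded chain carbon. The same group entering in place of naphthalen-1-yl gave a number 1 percentage points higher from compound 1 to compound 3 (within the scatter) and so this place can move the read-out, though not in every pair of compounds. Nothing measured here bears on why this step moved the number. From the compounds shown here alone, whether a plain phenyl or a pyridine ring at this place would also raise the number remains open.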